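A few compounds are considered here, and "the series" means these few. Any claim that something is new, unique, unknown or untested is made for them only; others in the source may bear on it.

Measured so far in a functional assay on KB-V1 cells (Homo sapiens) for cytotoxicity, read by MTT assay, with a stated time of 72 h; a lower number here means a stronger inhibitor, a higher number a weaker inhibitor:
Compound 1 `O=C1Nc2ccccc2/C1=N/NC(=S)Nc1ccc2c(c1)CCC2`: 2850 nM
Compound 2 `O=C1Nc2ccccc2/C1=N/NC(=S)NCc1ccccc1`: 7630 nM
Compound 3 `C=CCNC(=S)N/N=C1\C(=O)Nc2ccccc21`: 20700 nM

Of these three, compound 3 has the highest number and is the weakest inhibitor. Compound 4 `O=C1Nc2ccccc2/C1=N/NC(=S)Nc1ccc(Cl)cc1` has not yet been measured. It places 4-chlorophenyl in place of allyl on an amide-type nitrogen.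

Among the compounds with values here, the one measured step that bears closely on this change is a 2.7-fold higher number from compound 2 to compound 3 (0.43 log units; beyond the scatter), where vinyl stands in place of phenyl on a saturated chain carbon. That step is modest but beyond the scatter, and read in reverse it lowers the number. Among the measured compounds, set against compound 3, compound 1 also has a lower number, reaching 2850 nM. Within the data shown here, no measured compound carries 4-chlorophenyl, so the size of the change remains uncertain. A clear move to a lower number is expected in this assay, larger than the modest measured step. The expected change is a 6.9-fold lower number from compound 3 to compound 4 (0.84 log units; beyond the scatter). The estimate for compound 4 is 3000 nM, with an expected range of 1000 nM to 8000 nM.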

Compound 4, half-maximal inhibitory concentration: 4990 nM
The estimate for compound 4 lay 1.7-fold (0.22 log units) below the measured number; measured number inside the range.
By their numbers in this assay, from the lowest: compounds 1, 4 and 2 (each within the scatter of the next, the first and the last beyond it); then compound 3.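

In this assay, an aromatic ring of carbon only on the amide-type nitrogen gives a clear gain over allyl, with a 4.1-fold lower number from compound 3 to compound 4 (0.62 log units; beyond the scatter). Against benzyl, the 4-chlorophenyl group shows no real difference, with a 1.5-fold lower number from compound 2 to compound 4 (0.18 log units; within the scatter), so the ring set directly on this nitrogen and the ring carried on one chain carbon cannot be told apart here. Nothing shown gives a measured reason for either step.

The compounds shown include no plain phenyl on this nitrogen, so the share of the chlorine in the gain over allyl cannot be read. They also leave open how a methoxy group on the ring, or a longer chain ending in an amine, would compare at this place.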